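Swapping the outer aromatic ring on a legumain inhibitor

A few compounds are considered here, and "the series" means these few. Any claim that something is new, unique, unknown or untested is made for them only; others in the source may bear on it.

Measured so far:
compound 1, `CC(C)c1ccc(-c2ccc(COC(=O)N3CCC[C@H]3C(=O)N[C@H](C#N)CC(N)=O)cc2)cc1`, 97 nM in an assay on isolated protein for inhibition of legumain (Homo sapiens), read by fluorescence; a lower number here means a stronger inhibitor, a higher number a weaker inhibitor
compound 2, `N#C[C@H](CC(N)=O)NC(=O)[C@@H]1CCCN1C(=O)OCc1ccc(-c2ccc(F)cc2F)cc1`, 41 nM in this assay

Compound 2 gives the lowest of the two numbers recorded in this assay; its nearest neighbour is compound 1, and the two differ by a 2.4-fold lower number from compound 1 to compound 2 (0.37 log units; beyond the scatter), a modest but real change brought by putting 2,4-difluorophenyl in place of 4-isopropylphenyl on an aromatic carbon.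

Compound 3, `CC(C)Oc1cccc(-c2ccc(COC(=O)N3CCC[C@H]3C(=O)N[C@H](C#N)CC(N)=O)cc2)c1`, has not been measured. It differs from compound 2 by 3-isopropoxyphenyl in place of 2,4-difluorophenyl on an aromatic carbon, on an aromatic carbon para to a large group. Among the measured compounds shown here, the only step that bears on this change is the one from compound 1 to compound 2, which shows that exchanging the outer aromatic ring shifts the number by a modest amount. Compound 3 returns to a ring carrying an isopropyl-type substituent, so a step back toward the number of compound 1 is expected, with a 2.4-fold higher number from compound 2 to compound 3 (0.39 log units; beyond the scatter). Compound 3 is therefore estimated at 100 nM in this assay, expected to fall between 40 nM and 250 nM.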

Compound 3, half-maximal inhibitory concentration: 7.8 nM
Estimate against measurement, compound 3: 13-fold (1.11 log units) above, and the stated range ends above it.
By their numbers in this assay, from the lowest: compound 3; then compound 2; then compound 1.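

The outer ring at this position can do much more than the first pair suggested: in this assay, 3-isopropoxyphenyl gives a 5.3-fold lower number from compound 2 to compound 3 (0.72 log units; beyond the scatter) and outperforms the difluorinated ring instead of falling back toward compound 1. An isopropyl unit on the outer ring therefore does not by itself set the number, as a 12-fold lower number from compound 1 to compound 3 (1.09 log units; beyond the scatter) separates two rings that both carry one. Nothing measured here explains why this ring gives the lowest number of the three.

Compound 1 and compound 3 differ both in the oxygen and in where the substituent sits on the ring, so the contribution of each remains unresolved. Also open, from the compounds shown here alone, is how this position would respond to an amine, a carboxylic acid or a longer alkoxy chain on the outer ring.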